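Swapping the amide amine on a nitro-sulfonyl benzoyl piperidine scaffold

This account rests on a few compounds, and the source may have more. Where it says the series, first, only, none or still open, it means among the compounds named here.

Compound 1 `CN(Cc1ccccc1F)C(=O)C1CCN(C(=O)c2ccc(S(C)(=O)=O)c([N+](=O)[O-])c2)CC1` and compound 2 `CN1CCN(C(=O)C2CCN(C(=O)c3ccc(S(C)(=O)=O)c([N+](=O)[O-])c3)CC2)CC1` share a core and differ only in the amine attached to one carbonyl carbon. In an assay on isolated protein for inhibition of thyroid hormone receptor alpha (Homo sapiens), read by fluorescence polarization (on this read-out lower numbers stand for stronger inhibition and higher numbers for weaker inhibition), compound 1 gives > 60000 nM, which is a limit of the assay rather than a number. In this assay compound 2 likewise gives > 60000 nM, again a limit. The step that the two limits leave unreadable from compound 1 to compound 2 therefore cannot be read; both values sit at the limit of > 60000 nM in this assay, at which 2 of the 2 values shown sit. Compound 2 thus stands only at a limit, with no measured number to place it. Compound 3 `CC1Cc2ccccc2N1C(=O)C1CCN(C(=O)c2ccc(S(C)(=O)=O)c([N+](=O)[O-])c2)CC1` carries 2-methyl-2,3-dihydro-1H-indol-1-yl in place of 4-methylpiperazin-1-yl on a carbonyl carbon. No measured step bears on this change, since the single step shown is unreadable. The step that the limit leaves unreadable from compound 2 to compound 3 is expected to stay within the scatter, with compound 3 most likely again reported as a limit. Compound 3 is estimated at 80000 nM, in the range 15000 nM to 300000 nM.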

Compound 3, half-maximal inhibitory concentration: > 60000 nM
Compound 3 was reported as a limit (the forecaster's own chance of this, stated with the estimate: 80%); the middle value is on the limit's open side.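

In this assay compound 3 gives > 60000 nM, a limit of the assay and not a number. The steps from compound 1 and compound 2 to compound 3 therefore cannot be read, as all three compounds sit at one limit: the limit of > 60000 nM in this assay, at which 3 of the 3 values shown sit. The compounds shown leave open whether any amine on this carbonyl carbon gives a measurable value.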